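This account rests on a few compounds, and the source may have more. Where it says the series, first, only, none or still open, it means among the compounds named here.

Compound 3, `CCC(C(=O)NCc1ccccc1)N1C(=O)CCC1=O`, is one of three compounds whose effect on the whole animal was examined. In a functional assay on the whole organism (strain Albino Swiss CD1) with Mus musculus as the target (on this read-out lower numbers stand for an effect already at smaller amounts and higher numbers for an effect only at larger amounts of compound), compound 3 gives 90.3 mg/kg, the highest of the two numbers recorded. Its nearest neighbour is compound 1, `CC(C(=O)NCc1ccc(Cl)cc1)N1C(=O)CCC1=O`, which in this assay gives 43.6 mg/kg, a number lower than that of compound 3 by a margin that lies beyond the usual scatter; the two compounds differ in more than one place, so no single step can be read from them. Compound 2, `CC(C(=O)NCc1cccc(C(F)(F)F)c1)N1C(=O)CCC1=O`, was run but no result was reported for it in this assay, so it gives no value to compare: "not determined" (no result reported).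

Compound 4, `CCC(C(=O)NCc1cccc(F)c1)N1C(=O)CCC1=O`, is the next compound to be measured. It differs from compound 3 in one place: fluoro in place of hydrogen on an aromatic carbon, sitting on an aromatic carbon of the six-membered aromatic ring of carbon only, meta to a large group. Going by the values given here, no measured pair shows this change on its own. The estimate for compound 4 in this assay is 70 mg/kg, expected to lie between 35 mg/kg and 140 mg/kg. That would mean an expected step from compound 3 to compound 4 of a 1.3-fold lower number from compound 3 to compound 4 (0.11 log units; within the scatter), a modest move toward a lower number, because compound 1 with its halogen on the ring gives 43.6 mg/kg while the unsubstituted ring of compound 3 gives 90.3 mg/kg; the step may well stay within the scatter.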

Compound 4, dose for half-maximal effect: 47.4 mg/kg
Compound 4: middle estimate off by 1.5-fold (0.17 log units), on the high side; measured number inside the range.
By their numbers in this assay, from the lowest: compounds 1, 4 and 3 (each within the scatter of the next, the first and the last beyond it).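

Going by these compounds alone, the change from hydrogen to fluoro on an aromatic carbon, meta to a large group, is the first change in a single place that can be read. In this assay it gives a step that stays inside the usual scatter (a 1.9-fold lower number from compound 3 to compound 4 (0.28 log units; within the scatter)), so the measurement does not separate compound 4 from compound 3 and shows that this ring position tolerates fluoro without a clear loss or gain in the whole animal. Nothing at hand gives a reason for this step.

The compounds shown leave open whether a larger atom such as chlorine, or a group such as methoxy or an amine, would give a step beyond the scatter at this same place. They also leave open how fluoro would behave elsewhere on the ring.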